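The compounds below may be only part of what the source reports. "The series", "measured", "known", "first", "only" and "open" are said of these compounds alone.

Compounds measured so far in a functional assay on MCF7 cells (Homo sapiens) for inhibition, read by sulforhodamine B assay, with a stated time of 72 h; on this read-out higher numbers stand for weaker inhibition and lower numbers for stronger inhibition:
- compound 1, `Cc1ccc(C2=Nn3c(nnc3C(C)c3ccc(-c4ccccc4)c(F)c3)SC2)cc1`: 5000 nM
- compound 2, `COc1ccc2cc(C(C)c3nnc4n3N=C(c3ccc(Br)cc3)CS4)ccc2c1`: 11500 nM
- compound 3, `CC(C)Cc1ccc(C(C)c2nnc3n2N=C(c2ccc(C(F)(F)F)cc2)CS3)cc1`: 4200 nM

The three compounds share one core and differ in the aryl group on the carbon with a double bond to nitrogen and in the group attached to the other side. Among them compound 3 gives the lowest of the three numbers, but the value of compound 1 sits within the usual scatter of it, so the two cannot be ranked against each other. Compound 2 gives the highest number, and its gap to compound 3 lies beyond the scatter.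

Compound 4, `CC(C)Cc1ccc(C(C)c2nnc3n2N=C(c2ccc(Cl)cc2Cl)CS3)cc1`, keeps the core of compound 3 and differs from it in one place: 2,4-dichlorophenyl in place of 4-(trifluoromethyl)phenyl on a carbon with a double bond to nitrogen. Within the data shown here, no measured pair shows what this kind of exchange does in this assay, so the expectation for compound 4 rests on the value of compound 3 alone, which stands at 4200 nM. Without a comparable step in hand, the step from compound 3 to compound 4 is expected to be small, a 1.2-fold higher number from compound 3 to compound 4 (0.08 log units; within the scatter), most likely none beyond the scatter. Compound 4 is therefore estimated at 5000 nM, within a range from 2000 nM to 14000 nM.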

Compound 4, half-maximal inhibitory concentration: 11800 nM
For compound 4 the middle estimate is 2.4-fold (0.37 log units) below the measured one; the range from low to high includes it.
By their numbers in this assay, from the lowest: compounds 3 and 1 (each within the scatter of the next); then compounds 2 and 4 (each within the scatter of the next).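

In this assay, among these compounds, the step of a 2.8-fold higher number from compound 3 to compound 4 (0.45 log units; beyond the scatter) is the first comparison in which only the aryl group on the carbon with a double bond to nitrogen changes, and the rest of the molecule stays the same. The earlier compounds shown here differ in more than one place, so they could not separate the contribution of this position from that of the group on the other side of the core. This pair shows that the position is sensitive to the identity of its aryl group, since replacing 4-(trifluoromethyl)phenyl with 2,4-dichlorophenyl gives a modest weakening that lies beyond the scatter, and no measured property at hand accounts for it.

The compounds shown leave open whether one chlorine on the phenyl ring would give a number closer to that of compound 3 or compound 4, and how a phenyl ring bearing an amine or a carboxylic acid would behave at this position. Among the compounds shown here, they also leave open whether the same exchange would produce a similar step if the group on the other side of the core were the one carried by compound 1.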